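Working notes on compound 4 and its three measured analogues

The compounds below may be only part of what the source reports. "The series", "measured", "known", "first", "only" and "open" are said of these compounds alone.

Measured so far:
compound 1, `C/N=C(/NC#N)NCCCn1nc(-c2ccccc2)ccc1=O`, in a functional assay on the whole organism with Rattus norvegicus as the target (on this read-out higher numbers stand for an effect only at larger amounts of compound and lower numbers for an effect already at smaller amounts), gives 78.1 mg/kg
compound 2, `C/N=C(/NC#N)NCCCCCn1nc(-c2ccccc2)ccc1=O`, gives 76.2 mg/kg
compound 3, `N#CNC(=N)NCCCCn1nc(-c2ccccc2)ccc1=O`, gives 59.3 mg/kg

Compound 3 gives the lowest of the three numbers, but its nearest neighbour compound 2 and its furthest neighbour compound 1 both lie within the scatter of it, so no order among the three can be claimed. The two steps that end at compound 3 are a 1.3-fold lower number from compound 1 to compound 3 (0.12 log units; within the scatter) and a 1.3-fold lower number from compound 2 to compound 3 (0.11 log units; within the scatter); neither leaves the scatter.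

Compound 4, `C/N=C(\S)NCCCn1nc(-c2ccccc2)ccc1=O`, differs from compound 3 by a group of 5 heavy atoms (2 carbon, 2 nitrogen, 1 sulfur; no ring) in place of a group of 7 heavy atoms (3 carbon, 4 nitrogen; no ring), on a saturated chain carbon, three bonds along the chain from an aromatic nitrogen. Among the measured compounds shown here, both measured exchanges of the group on the chain attached to the aromatic nitrogen left the read-out within the scatter, and nothing among the measured compounds separates the length of the chain from the group exchanged. For the measured compounds named here, no measured compound carries the entering group, so the measured steps bear on this change only as a sign that exchanges at this position have so far been small. The expected step is a 1.2-fold higher number from compound 3 to compound 4 (0.07 log units; within the scatter), nothing beyond the scatter. Compound 4 is estimated at 70 mg/kg, with a range from 35 mg/kg to 140 mg/kg.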

Compound 4, dose for half-maximal effect: 58 mg/kg
For compound 4 the middle estimate is 1.2-fold (0.08 log units) above the measured one, within the range that was stated.
By their numbers in this assay, from the lowest: compounds 4, 3, 2 and 1 (each within the scatter of the next).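

In this assay, the only sulfur-bearing group shown, placed on a saturated chain carbon, three bonds along the chain from an aromatic nitrogen, gives a 1.0-fold lower number from compound 3 to compound 4 (0.01 log units; within the scatter), although the entering group has fewer heavy atoms, fewer hydrogen-bond donors and acceptors, and no triple bond. With the chain length unchanged, the exchange on an amine nitrogen gives a 1.3-fold lower number from compound 1 to compound 4 (0.13 log units; within the scatter), so this change can now be read apart from chain length, and it also leaves the read-out within the scatter. No evidence is available on what lies behind these small steps.

The effect of chain length on the sulfur-bearing group remains unread: the compounds shown carry it on one chain only, and a longer chain bearing the same group would be needed to test this. Going by these compounds, whether a primary amine or a carboxylic acid in this place would take this assay beyond the scatter also stays open.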